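The source may report more compounds than this note shows. Statements on the series, on what has been measured and on what is new or still open speak of the compounds shown alone.

Measured compounds:
- Compound 1, `CC(=NNC(=S)Nc1cccc([N+](=O)[O-])c1)c1ccccn1`: 69 nM
- Compound 2, `CC(=NNC(=S)Nc1cccc(F)c1)c1ccccn1`: 18 nM
- Compound 3, `C/C(=N/NC(=S)Nc1ccc([N+](=O)[O-])cc1)c1ccccn1`: 160 nM

All three were tested in a functional assay on U-87MG ATCC cells (Homo sapiens) for cytotoxicity, read by MTT assay, with a stated time of 48 h; on this read-out higher numbers stand for weaker inhibition and lower numbers for stronger inhibition. Compound 2 gives the lowest number, and compound 3 the highest, with compound 1 between them; each gap lies beyond the usual scatter.

Compound 1 and compound 2 differ in one place: fluoro in place of nitro on an aromatic carbon. That change gave a 3.8-fold lower number from compound 1 to compound 2 (0.58 log units; beyond the scatter).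

Compound 3 and compound 1 are built from the same atoms joined differently; the difference between their cores is not broken down here. Their values show compound 3 giving the higher number of the two.

Compound 4, `C/C(=N/NC(=S)Nc1ccc(F)cc1)c1ccccn1`, is not yet measured. It differs from compound 3 as follows: fluoro in place of nitro on an aromatic carbon. This is the same kind of change as that from compound 1 to compound 2, but not the same: in the earlier pair the place is "meta to a large group", while here it is "para to a large group".

The expectation for compound 4 rests on compound 1 and the step of a 3.8-fold lower number from compound 1 to compound 2 (0.58 log units; beyond the scatter), applied to the value of compound 3. The expected step is a 3.8-fold lower number from compound 3 to compound 4 (0.58 log units; beyond the scatter). On this basis compound 4 is estimated at 42 nM, with the likely range running from 20 nM to 90 nM, the width allowing for the different place around the change.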

Compound 4, half-maximal inhibitory concentration: 10 nM
Estimate against measurement, compound 4: 4.2-fold (0.62 log units) above, and the stated range ends above it.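

In this assay, putting fluoro in place of nitro, on an aromatic carbon para to a large group, gave a 16-fold lower number from compound 3 to compound 4 (1.20 log units; beyond the scatter). Set beside the earlier pair, this shows that the direction of the change carried over from one core to the other, while its size did not, so a step measured on one core gave only a rough guide to the step on the other: the same change on two cores in this assay, a 3.8-fold lower number (0.58 log units; beyond the scatter) from compound 1 to compound 2 and a 16-fold lower number (1.20 log units; beyond the scatter) from compound 3 to compound 4, 4.2-fold (0.62 log units) apart, beyond the scatter of two such steps. Among these compounds, with only two pairs, the result does not show whether the larger step belongs to the place of the change on the aromatic ring or to some other feature of the core, as the two pairs differ in that place and the data do not separate these possibilities, nor does it give any reason for the gap.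

The compounds shown compare only nitro and fluoro, so it remains open how an amine, a carboxylic acid or a longer chain at the same place would behave, and whether such groups would also give different steps on the two cores. All the numbers also come from one cell line, which leaves open whether the same order of compounds would hold in other cells.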